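Pyrimidinyl Piperazine Variant of a Benzamide Dithiocarbamate

A few compounds are considered here, and "the series" means these few. Any claim that something is new, unique, unknown or untested is made for them only; others in the source may bear on it.

Of the compounds shown here, three sharing one core have been tested in a functional assay on MGC-803 cells (Homo sapiens) for antiproliferative activity, read by CCK-8 assay, with a stated time of 72 h, tested at 8 uM; on this read-out higher numbers stand for a stronger effect at the one concentration tested and lower numbers for a weaker effect. Compound 1 `Nc1ccccc1NC(=O)c1ccc(CSC(=S)N2CCN(c3ccc(Cl)cc3)CC2)cc1` gives 17.2% in this assay. Compound 2 `Nc1ccccc1NC(=O)c1ccc(CSC(=S)N2CCN(c3cccnc3)CC2)cc1` gives 76.9%, and compound 3 `Nc1ccccc1NC(=O)c1ccc(CSC(=S)N2CCN(Cc3ccncc3)CC2)cc1` gives 79.3%. The change from compound 1 to compound 2 brought a number 59.7 percentage points higher from compound 1 to compound 2 (beyond the scatter), and the change from compound 1 to compound 3 brought a number 62.1 percentage points higher from compound 1 to compound 3 (beyond the scatter), whereas between the two pyridine-bearing compounds there was only a number 2.4 percentage points higher from compound 2 to compound 3 (within the scatter). Compound 3 therefore sits far above compound 1 and alongside compound 2.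

Compound 4 `Nc1ccccc1NC(=O)c1ccc(CSC(=S)N2CCN(c3ncccn3)CC2)cc1` differs from compound 3 in one place: pyrimidin-2-yl in place of (pyridin-4-yl)methyl on an amine nitrogen in a ring. Both measured steps that replaced 4-chlorophenyl by a pyridine-containing group were large gains, and whether that group was attached through a methylene or directly made no difference beyond the scatter. A second nitrogen-bearing aromatic ring placed directly on the ring nitrogen is expected to behave more like compound 2 than like compound 1, so compound 4 is estimated to show a number 14.3 percentage points lower from compound 3 to compound 4 (beyond the scatter). Compound 4 is accordingly expected to give about 65%, within a range of 40% to 85%.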

Compound 4, a percentage reported as inhibition, at one concentration (the size of the read-out at that concentration, not a potency): 64.8%
Beside the measured number, compound 4's estimate is 0.2 percentage points above it; low and high end bracket the measured number.
By their numbers in this assay, from the lowest: compound 1; then compound 4; then compounds 2 and 3 (each within the scatter of the next).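

In this assay, the change to pyrimidin-2-yl gave a number 14.5 percentage points lower from compound 3 to compound 4 (beyond the scatter) and, against the directly attached pyridine, a number 12.1 percentage points lower from compound 2 to compound 4 (beyond the scatter), so this amine nitrogen does not treat every nitrogen-bearing aromatic ring alike, although compound 2 and compound 3 lay within the scatter of each other. The same group still gave a number 47.6 percentage points higher from compound 1 to compound 4 (beyond the scatter), so a ring with two hetero atoms keeps compound 4 well clear of the 4-chlorophenyl compound. Nothing available here accounts for the shortfall of the pyrimidin-2-yl group against the two pyridine-bearing groups.

The compounds shown leave open how an unsubstituted phenyl or a benzyl group would compare at this nitrogen. They also leave open whether a pyridin-2-yl ring would stand with compound 2 or with compound 4.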